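This account rests on a few compounds, and the source may have more. Where it says the series, first, only, none or still open, it means among the compounds named here.

In a functional assay on HepG2 cells (Homo sapiens) for antiproliferative activity, read by MTT assay, with a stated time of 48 h (on this read-out lower numbers stand for stronger inhibition and higher numbers for weaker inhibition), compound 1 `CCn1c(C(=O)NCC#N)ccc1C(CC)(CC)c1ccc(OCCC(O)(CC)CC)c(C)c1` gives > 50000 nM, which is a limit and not a number. Compound 2 `CCn1c(C(=O)Nc2ccc(OC(F)(F)F)cc2)ccc1C(CC)(CC)c1ccc(OCCC(O)(CC)CC)c(C)c1` gives > 50000 nM, also a limit. Among the compounds with values here, the only measured change, 4-(trifluoromethoxy)phenyl in place of cyanomethyl on an amide-type nitrogen, is therefore a step that the two limits leave unreadable from compound 1 to compound 2, and both compounds rest at the limit of > 50000 nM in this assay, at which 2 of the 2 values shown sit. Compound 3 `CCOC(=O)CN(C)C(=O)c1ccc(C(CC)(CC)c2ccc(OCCC(O)(CC)CC)c(C)c2)n1CC` has ((ethoxycarbonyl)methyl)(methyl)amino in place of (4-(trifluoromethoxy)phenyl)amino on a carbonyl carbon. Within the data shown here, no measured step gives a size or direction to carry over, so the expected step is a number no higher from compound 2 to compound 3 (the limit leaves the size open). For compound 3 the estimated value is 50000 nM, with an expected range from 20000 nM to 120000 nM.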

Compound 3, half-maximal inhibitory concentration: 25300 nM
Beside the measured number, compound 3's estimate is 2.0-fold (0.30 log units) above it; measured number inside the range.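

Within the data shown here, the change on this carbonyl carbon yields the only readable number in this assay, with an at least 1.9-fold lower number from compound 2 to compound 3 (0.29 log units; that floor lies within the scatter) and an at least 1.9-fold lower number from compound 1 to compound 3 (0.29 log units; that floor lies within the scatter). Both floors lie within the scatter. This is only a hint of activity, not a proven gain. Compound 3 alone leaves the limit, which is the one shared by the other two compounds: the limit of > 50000 nM in this assay, at which 2 of the 3 values shown sit.

The compounds shown leave open how large either step truly is, since compound 1 and compound 2 have no exact values. They also leave open whether the ethoxycarbonyl part matters, or whether a carboxylic acid in its place would read differently.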